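Halogen exchange on the fused ring of compound 3

The source may hold more compounds than are shown below. What is called first, only, known or untested is meant among the compounds shown, and "the series" means these compounds.

Measured in an assay on HeLa cells for displacement of a labelled ligand from 5-hydroxytryptamine receptor 6 (Homo sapiens); on this read-out lower numbers stand for stronger inhibition and higher numbers for weaker inhibition:
compound 1 `CSc1nc2ccccn2/c(=N\C(C)=O)c1S(=O)(=O)c1ccccc1` gives 83 nM
compound 2 `CSc1nc2ccccn2c(=O)c1S(=O)(=O)c1ccccc1` gives 52 nM
compound 3 `CSc1nc2ccc(F)cn2c(=N)c1S(=O)(=O)c1ccccc1` gives 28 nM

Compound 3 stands at the lowest of the three numbers. Its gap to compound 2 lies within the scatter, so no order between these two can be read; its gap to compound 1 lies beyond the scatter. The three measured compounds differ from one another at more than one place, so no single change among them is isolated.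

Compound 4 `CSc1nc2ccc(Br)cn2c(=N)c1S(=O)(=O)c1ccccc1` differs from compound 3 in one place: bromo in place of fluoro on an aromatic carbon of the six-membered aromatic ring with one nitrogen, two atoms from the ring nitrogen, meta to a fused ring and para to a fused ring. Going by the values given here, no pair of measured compounds covers this exchange, so nothing measured tells how swapping one halogen for another at this position moves the number in this assay. With one halogen replacing another and no change in donors, acceptors or charge, the expected step is a 1.1-fold lower number from compound 3 to compound 4 (0.05 log units; within the scatter), which is none beyond the scatter, with the direction left open. For compound 4 the estimate in this assay is 25 nM, with a range from 9 nM to 70 nM.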

Compound 4, half-maximal inhibitory concentration: 56 nM
Compound 4: middle estimate off by 2.2-fold (0.35 log units), on the low side; the measured number falls inside the stated range.
By their numbers in this assay, from the lowest: compounds 3, 2, 4 and 1 (each within the scatter of the next, the first and the last beyond it).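

Bromo in place of fluoro on an aromatic carbon of the six-membered aromatic ring with one nitrogen is the only single-place exchange in this set, and it makes one change at this position readable in this assay: the step is a 2.0-fold higher number from compound 3 to compound 4 (0.30 log units; within the scatter). The earlier compounds shown here could say nothing about this position in isolation, whereas this pair shows that the two halogens cannot be ranked here, so fluoro and bromo on the core of compound 3 stay indistinguishable on this read-out. Nothing available bears on why the two numbers fall where they do.

The compounds shown leave open how other groups at this position would read, such as chloro, methoxy, an amine or a carboxylic acid, and how a plain hydrogen there would compare with either halogen on the core of compound 3. Also open, going by these compounds, is whether bromo in place of fluoro would give a step of similar size on the core of compound 1 or on the core of compound 2, where the group on the ring carbon bearing the imine differs.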